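Swapping an Amide for an Amine on the Ring Nitrogen

The compounds below may be only part of what the source reports. "The series", "measured", "known", "first", "only" and "open" are said of these compounds alone.

Three compounds have been measured in an assay on CHO cells for displacement of a labelled ligand from Substance-P receptor (Homo sapiens); on this read-out higher numbers stand for weaker inhibition and lower numbers for stronger inhibition:

Compound 1 `CN(Cc1cc(C(F)(F)F)cc(C(F)(F)F)c1)C(=O)[C@H]1CN(C(=O)C2CCNCC2)C[C@@H]1c1ccccc1` gives 4.1 nM.
Compound 2 `CN(Cc1cc(C(F)(F)F)cc(C(F)(F)F)c1)C(=O)[C@H]1CN(C(=O)NC2CCCCC2)C[C@@H]1c1ccccc1` gives 0.79 nM.
Compound 3 `CN(Cc1cc(C(F)(F)F)cc(C(F)(F)F)c1)C(=O)[C@H]1CN(C(=O)C2CCCCC2)C[C@@H]1c1ccccc1` gives 0.68 nM.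

Compound 3 has the lowest number of the three, but its step to compound 2 is within the scatter: a 1.2-fold lower number from compound 2 to compound 3 (0.07 log units; within the scatter). Only compound 1 stands clearly apart, with a 6.0-fold lower number from compound 1 to compound 3 (0.78 log units; beyond the scatter) and a 5.2-fold lower number from compound 1 to compound 2 (0.72 log units; beyond the scatter).

Compound 4 `CN(Cc1cc(C(F)(F)F)cc(C(F)(F)F)c1)C(=O)[C@H]1CN(CC2CCCCC2)C[C@@H]1c1ccccc1` is the next structure. It differs from compound 3 in one place: cyclohexylmethyl in place of cyclohexylcarbonyl on an amine nitrogen in a ring. The change removes the carbonyl between the ring nitrogen and the six-membered ring.

Going by the values given here, none of the measured steps bears on this directly. All three steps exchange the group on a carbonyl carbon and keep the carbonyl itself; none removes it. Among the compounds with values here, the two steps that were beyond the scatter were both modest in size, and the one swap among groups of similar size was within the scatter. Within the data shown here, with no measured step touching the carbonyl, the expectation for compound 4 is wide and cannot lean firmly either way.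

Compound 4 is therefore expected to give 4 nM in this assay, with a range from 0.6 nM to 30 nM, which means an expected step of a 5.9-fold higher number from compound 3 to compound 4 (0.77 log units; beyond the scatter).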

Compound 4, half-maximal inhibitory concentration: 62 nM
Compound 4: middle estimate off by 16-fold (1.19 log units), on the low side; the measured number lies above the stated range.
By their numbers in this assay, from the lowest: compounds 3 and 2 (each within the scatter of the next); then compound 1; then compound 4.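

The carbonyl on the ring nitrogen turns out to matter far more in this assay than the group attached to it: exchanges on the carbonyl carbon gave modest steps or none beyond the scatter, whereas removing the carbonyl gives a 91-fold higher number from compound 3 to compound 4 (1.96 log units; beyond the scatter) and, against the cyclohexylcarbamoyl group, a 78-fold higher number from compound 2 to compound 4 (1.89 log units; beyond the scatter) in the same direction. The cyclohexane ring is still present in the cyclohexylmethyl group, yet the change gives a 15-fold higher number from compound 1 to compound 4 (1.18 log units; beyond the scatter) even against the (piperidin-4-yl)carbonyl group, which had the highest number until now, so having this ring on the ring nitrogen does not by itself keep the number low. Nothing available here explains why losing the carbonyl has so large an effect at this position.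

The compounds shown leave open whether a sulfonyl group could stand in for the carbonyl and keep the number low. They also leave open whether a piperidin-4-ylmethyl group would show a step of similar size from compound 1, or whether the large step belongs to the cyclohexyl series alone.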